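The compounds below may be only part of what the source reports. "The series", "measured", "known", "first", "only" and "open" are said of these compounds alone.

Measured in a functional assay on MCF7 cells (Homo sapiens) for antiproliferative activity, read by MTT assay, with a stated time of 72 h; a lower number here means a stronger inhibitor, a higher number a weaker inhibitor:
- compound 1 `COc1cc(-n2cnc3ccc(-c4ccc([N+](=O)[O-])cc4)cc32)cc(OC)c1OC` gives 740 nM here
- compound 2 `COc1cc(-n2cnc3ccc(-c4ccc(C(F)(F)F)cc4)cc32)cc(OC)c1OC` gives 760 nM here
- compound 3 `COc1cc(-n2cnc3ccc(-c4cccc(Cl)c4)cc32)cc(OC)c1OC` gives 3120 nM here

Compound 3 has the highest number of the three and is the weakest of them in this assay on these data. Compound 4 `COc1cc(-n2cnc3ccc(-c4ccc(C)cc4)cc32)cc(OC)c1OC` is still unmeasured. It carries 4-methylphenyl in place of 3-chlorophenyl on an aromatic carbon.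

Within the data shown here, two measured steps bear on this change, both modest and beyond the scatter: a 4.2-fold higher number from compound 1 to compound 3 (0.62 log units; beyond the scatter) and a 4.1-fold higher number from compound 2 to compound 3 (0.61 log units; beyond the scatter). Each ends at 3-chlorophenyl, one starting from 4-nitrophenyl and the other from 4-(trifluoromethyl)phenyl. The step of a 1.0-fold higher number from compound 1 to compound 2 (0.01 log units; within the scatter) lies within the scatter, so those two groups show no order. Among the measured compounds shown here, no measured compound carries 4-methylphenyl, so only part of the reverse of those steps is assumed.

The expected change is a 2.8-fold lower number from compound 3 to compound 4 (0.45 log units; beyond the scatter), a modest move to a lower number. The estimate for compound 4 is 1100 nM, with an expected range from 450 nM to 2800 nM in this assay.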

Compound 4, half-maximal inhibitory concentration: 110 nM
Beside the measured number, compound 4's estimate is 10-fold (1.00 log units) above it; measured number below the stated range.
By their numbers in this assay, from the lowest: compound 4; then compounds 1 and 2 (each within the scatter of the next); then compound 3.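

In this assay, among these compounds, 4-methylphenyl in place of 3-chlorophenyl gives a 28-fold lower number from compound 3 to compound 4 (1.45 log units; beyond the scatter), so the group at this position can move the number much further than the earlier steps showed. Among the groups carrying a 4-substituent, which earlier showed no order between 4-nitrophenyl and 4-(trifluoromethyl)phenyl, methyl now separates from both: a 6.9-fold lower number from compound 2 to compound 4 (0.84 log units; beyond the scatter) and a 6.7-fold lower number from compound 1 to compound 4 (0.83 log units; beyond the scatter), leaving compound 4 the strongest of the four. Nothing at hand accounts for these differences.

As far as these compounds go, the step to compound 4 changes both the substituent and where it sits, so the share of each stays open; 4-chlorophenyl and 3-methylphenyl would separate them. From the compounds shown here alone, whether an ethyl or methoxy group in place of the methyl of compound 4 would hold this number also stays open.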